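The source may report more compounds than this note shows. Statements on the series, on what has been measured and on what is new or still open speak of the compounds shown alone.

In a functional assay on HCT-116 cells (Homo sapiens) for cytotoxicity, read by MTT assay, with a stated time of 72 h (a higher number here means a weaker inhibitor, a lower number a stronger inhibitor), compound 1 `COc1ccc(S(=O)(=O)c2nc3ccccc3nc2Nc2cccc(N)c2)cc1` gives 3710 nM, and compound 2 `O=S(=O)(c1ccc(Br)cc1)c1nc2ccccc2nc1Nc1ccccc1` gives 1110 nM. Compound 3 `COc1cc(Nc2nc3ccccc3nc2S(=O)(=O)c2ccc(Br)cc2)cc(OC)c1` gives > 50000 nM, which is a limit of the assay and not a number.

Compound 4 `Nc1cccc(Nc2nc3ccccc3nc2S(=O)(=O)c2ccc(Br)cc2)c1` has not yet been measured. Its change is 3-aminophenyl in place of 3,5-dimethoxyphenyl on a nitrogen on an aromatic ring.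

Two measurements bear on this change. The first is a large step, an at least 45-fold higher number from compound 2 to compound 3 (1.65 log units; beyond the scatter), seen when 3,5-dimethoxyphenyl replaced phenyl, and compound 4 loses that same group. The second comes from compound 1, which already carries 3-aminophenyl and gives 3710 nM, although it differs from compound 4 elsewhere in its structure.

Together these point to a large move towards a lower number, meaning a stronger inhibitor, rather than a change within the scatter. The expected size of this move is an at least 20-fold lower number from compound 3 to compound 4 (1.30 log units; beyond the scatter). Compound 4 is estimated at about 2500 nM, with an expected range from 700 nM to 9000 nM.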

Compound 4, half-maximal inhibitory concentration: 3280 nM
Beside the measured number, compound 4's estimate is 1.3-fold (0.12 log units) below it, and the stated range covers the measured number.
By their numbers in this assay, from the lowest: compound 2; then compounds 4 and 1 (each within the scatter of the next). At a limit, above all of these: compound 3.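

In this assay, 3-aminophenyl in place of 3,5-dimethoxyphenyl on the nitrogen gives an at least 15-fold lower number from compound 3 to compound 4 (1.18 log units; beyond the scatter). Compound 3 sits at a limit of the assay and not at a number, so this size is only a minimum: the limit of > 50000 nM in this assay, at which 1 of the 4 values shown sits. The added amino group still leaves the compound weaker than the plain phenyl version, with a 3.0-fold higher number from compound 2 to compound 4 (0.47 log units; beyond the scatter), while bromo in place of methoxy gives two values that cannot be told apart, with a 1.1-fold lower number from compound 1 to compound 4 (0.05 log units; within the scatter).

The compounds shown leave open whether a single methoxy group on this ring would give a value as poor as that of compound 3 or one close to that of compound 2. From the compounds shown here alone, it also remains open whether a hydroxyl or an acetamide in place of the amino group would match compound 4.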